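A few compounds are considered here, and "the series" means these few. Any claim that something is new, unique, unknown or untested is made for them only; others in the source may bear on it.

Compound 1 `CC(C)c1cc(-c2n[nH]c(=O)n2-c2cccc(NC(=O)CCCCCC(=O)NO)c2)c(O)cc1O` and compound 2 `CC(C)c1cc(-c2n[nH]c(=O)n2-c2cccc(NC(=O)CCCCC(=O)NO)c2)c(O)cc1O` share a core; in a functional assay on HEL cells (Homo sapiens) for inhibition (a lower number here means a stronger inhibitor, a higher number a weaker inhibitor), compound 1 gives 1600 nM, and compound 2 gives 1600 nM. The step of no change at the digits printed from compound 1 to compound 2 (within the scatter) comes from hydroxycarbamoyl in place of (hydroxycarbamoyl)methyl on a saturated chain carbon, four bonds along the chain from a carbonyl carbon. Compound 3 `CC(C)c1cc(-c2n[nH]c(=O)n2-c2ccc(C(=O)NCCCCC(=O)NO)cc2)c(O)cc1O` carries a different core, and how that core differs from the core of compound 1 is not broken down here; in this assay compound 3 gives 4600 nM. Compound 4 `CC(C)c1cc(-c2n[nH]c(=O)n2-c2ccc(C(=O)NCCCC(=O)NO)cc2)c(O)cc1O` is derived from compound 3 by hydroxycarbamoyl in place of (hydroxycarbamoyl)methyl on a saturated chain carbon, three bonds along the chain from an amide-type nitrogen, the same kind of change, though here it sits three bonds along the chain from an amide-type nitrogen rather than four bonds along the chain from a carbonyl carbon. Because no change at the digits printed from compound 1 to compound 2 (within the scatter) showed no shift, the step of no change at the digits printed from compound 3 to compound 4 (within the scatter) is expected to be small as well. Compound 4 is therefore estimated at 4600 nM in this assay, between 2300 nM and 9200 nM.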

Compound 4, half-maximal inhibitory concentration: 4600 nM
Compound 4: middle estimate and measured number agree at the digits printed, and the stated range covers the measured number.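

In this assay, hydroxycarbamoyl in place of (hydroxycarbamoyl)methyl on the saturated chain gave no change at the digits printed from compound 3 to compound 4 (within the scatter). The same change thus behaved alike on the two cores: the same change on two cores in this assay, no change at the digits printed (within the scatter) from compound 1 to compound 2 and no change at the digits printed (within the scatter) from compound 3 to compound 4, 1.0-fold (0.00 log units) apart, within the scatter of two such steps. This holds only for these two cores and this one change, and it does not show that the change would stay without effect on any other core, nor why it has so little effect here.

The compounds shown leave open whether a chain longer than that of compound 1 would also leave the number in this assay in place. They also leave open what a carboxylic acid in place of the hydroxycarbamoyl group would give on either core.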